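Trifluoromethylphenyl in place of naphthyl on the thiazole arm

The source may hold more compounds than are shown below. What is called first, only, known or untested is meant among the compounds shown, and "the series" means these compounds.

Compound 3 `C=C(C)C(=O)c1ccc(OCc2nc(-c3ccc4ccccc4c3)cs2)c(C)c1C` stands second highest of three in an assay on HL-60 cells for inhibition of glutathione S-transferase P (Homo sapiens), read by spectrophotometry, tested at 5 uM (on this read-out higher numbers stand for more inhibition at the one concentration tested (going by the name of the read-out) and lower numbers for less inhibition), giving 11.3%. Its nearest neighbour is compound 2 `C=C(CC)C(=O)c1ccc(OCc2nc(-c3ccc(C(F)(F)F)cc3)cs2)c(C)c1C`, which gives 0% in this assay; furthest is compound 1 `C=C(C)C(=O)c1ccc(OCc2nc(-c3ccccc3)cs2)c(C)c1C`, which gives 100%. Within the data shown here, the one step that bears on the change was a number 88.7 percentage points lower from compound 1 to compound 3 (beyond the scatter). Compound 4 `C=C(C)C(=O)c1ccc(OCc2nc(-c3ccc(C(F)(F)F)cc3)cs2)c(C)c1C` differs from compound 3 by 4-(trifluoromethyl)phenyl in place of naphthalen-2-yl on an aromatic carbon. No single step to the entering group is available; compound 2 carries that same group but also differs elsewhere, and its value is the lowest shown. The account therefore expects compound 4 to remain low, with a step of a number 3.3 percentage points lower from compound 3 to compound 4 (within the scatter) that is expected to be small. Compound 4 is estimated at 8%, within 0% to 35%.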

Compound 4, a percentage reported as inhibition, at one concentration (the size of the read-out at that concentration, not a potency): 3.6%
Compound 4: middle estimate off by 4.4 percentage points, on the high side; the range from low to high includes it.
By their numbers in this assay, from the lowest: compounds 2, 4 and 3 (each within the scatter of the next, the first and the last beyond it); then compound 1.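

In this assay the step of a number 7.7 percentage points lower from compound 3 to compound 4 (within the scatter) shows that 4-(trifluoromethyl)phenyl and naphthalen-2-yl cannot be told apart on this aromatic carbon. The step of a number 96.4 percentage points lower from compound 1 to compound 4 (beyond the scatter) shows that trifluoromethyl alone on the phenyl group is enough to lose nearly all the inhibition, and a number 3.6 percentage points higher from compound 2 to compound 4 (within the scatter) leaves the methyl on the chain carbon without a readable effect at this low level. Nothing measured here gives a cause for this. On these data alone, whether fluorine or a methoxy group in place of trifluoromethyl would keep the inhibition stays open. So does whether an amine on the phenyl group would.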